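The source may report more compounds than this note shows. Statements on the series, on what has been measured and on what is new or still open speak of the compounds shown alone.

Working notes on the series. All compounds share one core with a saturated ring carbon whose substituent is varied. Compound 1 `Cc1cc(O)c(C2=NN(c3ccc(S(N)(=O)=O)cc3)C(/C=C/c3ccccc3)C2)cc1Cl` bears a 2-phenylethenyl group there; in a functional assay on Hs-578T cells (Homo sapiens) for antiproliferative activity, with a stated time of 48 h (on this read-out lower numbers stand for stronger inhibition of growth and higher numbers for weaker inhibition of growth), compound 1 gives 12300 nM. Compound 2 `COc1ccc(C2CC(c3cc(Cl)c(C)cc3O)=NN2c2ccc(S(N)(=O)=O)cc2)cc1OC` carries a 3,4-dimethoxyphenyl group in its place, and in this assay compound 2 gives 3290 nM. Going by the values given here, the step of a 3.7-fold lower number from compound 1 to compound 2 (0.57 log units; beyond the scatter) is the only measured step so far. Compound 2 therefore holds the lowest of the two numbers, with compound 1 as its nearest neighbour, set apart beyond the scatter.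

Compound 3 `COc1ccc(C2CC(c3cc(Cl)c(C)cc3O)=NN2c2ccc(S(N)(=O)=O)cc2)c(OC)c1OC` differs from compound 2 by methoxy in place of hydrogen on an aromatic carbon, on a six-membered aromatic ring of carbon only, ortho to a large group, ortho to a methoxy group and meta to a methoxy group; read one bond further out, 3,4-dimethoxyphenyl becomes 2,3,4-trimethoxyphenyl. Among the compounds with values here, no measured step bears on this change: the single step of a 3.7-fold lower number from compound 1 to compound 2 (0.57 log units; beyond the scatter) swaps the whole group on the saturated carbon and says nothing about an added methoxy on the aryl ring it brings in. The expectation for this assay is therefore a step not beyond the scatter, a 1.1-fold lower number from compound 2 to compound 3 (0.04 log units; within the scatter). Compound 3 is estimated at 3000 nM in this assay, within 1200 nM to 8000 nM.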

Compound 3, concentration for 50% growth inhibition: 2210 nM
The estimate for compound 3 lay 1.4-fold (0.13 log units) above the measured number, and the stated range covers the measured number.
By their numbers in this assay, from the lowest: compounds 3 and 2 (each within the scatter of the next); then compound 1.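

Adding methoxy in place of hydrogen on an aromatic carbon, ortho to a large group, turns 3,4-dimethoxyphenyl into 2,3,4-trimethoxyphenyl and gives, in this assay, a 1.5-fold lower number from compound 2 to compound 3 (0.17 log units; within the scatter), so this position accepts a further methoxy with no change in growth inhibition that can be told from the scatter. The replacement of 2-phenylethenyl on the saturated ring carbon now has a second reading, a 5.6-fold lower number from compound 1 to compound 3 (0.75 log units; beyond the scatter), and the advantage over the 2-phenylethenyl group therefore holds for both methoxy-substituted phenyl groups shown, with the third methoxy neither adding to it nor taking it away beyond the scatter. Nothing available explains either step.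

The compounds shown leave open whether this aromatic carbon responds at all to groups other than methoxy, such as an amine, a hydroxy group, a carboxylic acid or a longer chain like butoxy, since a single substituent within the scatter cannot show how wide that tolerance is. They also leave open whether a phenyl group with no methoxy on it, or a morpholine ring, would serve equally well on the saturated ring carbon.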